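The source may report more compounds than this note shows. Statements on the series, on what has been measured and on what is new or still open speak of the compounds shown alone.

Measured so far in a functional assay on cells (Panel leukemia (Carcinoma cell lines), Homo sapiens) for inhibition, read by sulforhodamine B assay, with a stated time of 48 h; a higher number here means that more compound is tolerated, a lower number that less compound is tolerated:
- compound 1 `CN1CCN(CCCOc2cccc3nc(Nc4ccc(Cl)c(F)c4)ccc23)CC1` gives 53900 nM
- compound 2 `CN1CCN(CCCOc2cccc3nc(Nc4ccc(F)c(F)c4)ccc23)CC1` gives 21100 nM

Compound 2 holds the lower of the two numbers. Among the compounds with values here, the only measured step is modest but beyond the scatter (a 2.6-fold lower number from compound 1 to compound 2 (0.41 log units; beyond the scatter)), and it exchanges chloro for fluoro on an aromatic carbon.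

Next in line is compound 3 `CN1CCN(CCCOc2cccc3nc(Nc4cccc(Cl)c4)ccc23)CC1`, which differs from compound 2 as follows (3-chlorophenyl in place of 3,4-difluorophenyl on a nitrogen on an aromatic ring): 3-chlorophenyl in place of 3,4-difluorophenyl on a nitrogen on an aromatic ring. Within the data shown here, no measured compound carries the 3-chlorophenyl group, so the one step bears on this change only in part. Compound 3 has a chloro and no fluoro, and the chloro-bearing compound 1 stands at 53900 nM in the same read-out. With a single pair, no pattern can be claimed. A small move to a higher number in this assay is still expected, no larger than the measured step and possibly lost in the scatter.

The expected step is small (a 1.4-fold higher number from compound 2 to compound 3 (0.15 log units; within the scatter)). For compound 3 the estimated value is 30000 nM with an expected range of 11000 nM to 80000 nM for repeat measurements.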

Compound 3, concentration lethal to 50% of the cells: 38000 nM
Beside the measured number, compound 3's estimate is 1.3-fold (0.10 log units) below it; the range from low to high includes it.
By their numbers in this assay, from the lowest: compounds 2, 3 and 1 (each within the scatter of the next, the first and the last beyond it).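

In this assay, the group on a nitrogen on an aromatic ring can be 3-chlorophenyl with the number staying within the scatter of both related compounds: the change from 3,4-difluorophenyl is a 1.8-fold higher number from compound 2 to compound 3 (0.26 log units; within the scatter), and the change from 4-chloro-3-fluorophenyl is a 1.4-fold lower number from compound 1 to compound 3 (0.15 log units; within the scatter). The earlier step, a 2.6-fold lower number from compound 1 to compound 2 (0.41 log units; beyond the scatter), therefore does not extend to a clear three-way ranking, since only compound 1 and compound 2 stand apart beyond the scatter, while compound 3 cannot be separated from either. No measurement available here accounts for where these values fall.

Still open, from the compounds shown here alone, is whether a different kind of group on this phenyl ring, such as methoxy, a nitrile or an amine, would move the number beyond the scatter, and how an unsubstituted phenyl would compare with these halogenated groups. The compounds shown also leave open what a longer chain, or a carboxylic acid in place of the amine at the end of the chain, would do to the number in this assay.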